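The compounds below may be only part of what the source reports. "The series", "measured", "known", "first", "only" and "open" are said of these compounds alone.

Measured compounds:
- compound 1 `CC(C(=O)NCc1ccc(C(F)(F)F)nc1N(C)S(=O)(=O)c1ccccc1)c1ccc(NS(C)(=O)=O)c(F)c1` gives 698 nM in an assay on CHO cells for displacement of a labelled ligand from transient receptor potential cation channel subfamily V member 1 (Homo sapiens), read by scintillation counting, with a stated time of 60 min; a lower number here means a stronger inhibitor, a higher number a weaker inhibitor
- compound 2 `CC(C(=O)NCc1ccc(C(F)(F)F)nc1N(Cc1ccccc1)S(=O)(=O)C(C)C)c1ccc(NS(C)(=O)=O)c(F)c1` gives 18.1 nM in this assay
- compound 3 `CC(C(=O)NCc1ccc(C(F)(F)F)nc1N(Cc1ccccc1)S(=O)(=O)c1ccc(F)cc1)c1ccc(NS(C)(=O)=O)c(F)c1` gives 1.56 nM in this assay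

Compound 3 stands at the lowest number of the three in this assay. Going by the values given here, compound 2 is its nearest neighbour, and the step of a 12-fold lower number from compound 2 to compound 3 (1.06 log units; beyond the scatter) is the one measured change that differs in a single place. Compound 1 differs from compound 3 in two places at once, so only the two values can be set side by side: in this assay compound 1 gives 698 nM, while compound 3 gives 1.56 nM.

Compound 4 `COc1ccc(CN(c2nc(C(F)(F)F)ccc2CNC(=O)C(C)c2ccc(NS(C)(=O)=O)c(F)c2)S(=O)(=O)c2ccc(F)cc2)cc1` differs from compound 3 by methoxy in place of hydrogen on an aromatic carbon. Among the compounds with values here, no measured step touches this part of the molecule: the only single-place step concerns the group on the sulfonyl sulfur, and the benzyl on the nitrogen is unchanged between compound 2 and compound 3. With nothing to point to a shift in either direction, compound 4 is expected to stay close to compound 3, with a step of a 1.3-fold higher number from compound 3 to compound 4 (0.11 log units; within the scatter) within the usual scatter. Compound 4 is therefore estimated at 2 nM in this assay, within 0.6 nM to 7 nM.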

Compound 4, inhibition constant: 1.65 nM
Beside the measured number, compound 4's estimate is 1.2-fold (0.08 log units) above it; low and high end bracket the measured number.
By their numbers in this assay, from the lowest: compounds 3 and 4 (each within the scatter of the next); then compound 2; then compound 1.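

The step of a 1.1-fold higher number from compound 3 to compound 4 (0.02 log units; within the scatter) in this assay lies within the scatter, and it is the first single-place change shown on the benzyl group, as the earlier step concerned only the group on the sulfonyl sulfur. It shows that this benzyl can become 4-methoxybenzyl, with methoxy on the aromatic carbon para to a large group, and the number stays within the scatter. No measurement at hand explains this outcome.

Going by these compounds, whether this holds for other groups at the same carbon stays open, since an amine, a carboxylic acid or a longer chain such as butoxy could behave differently. Also open, on these data alone, is whether methoxy would give the same result with isopropyl on the sulfonyl sulfur, as in compound 2.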